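The source may report more compounds than this note shows. Statements on the series, on what has been measured and on what is new or still open speak of the compounds shown alone.

Working notes on the series. In a functional assay on JAR cells (Homo sapiens) for inhibition, read by MTT assay, with a stated time of 72 h, tested at 10 uM (a lower number here means less inhibition, a higher number more inhibition at the concentration tested (going by the name of the read-out)), compound 1 `CCOC(=O)C1=C(Nc2ccccc2)S/C(=C\c2ccccc2)C1=O` gives 20.3%, the lowest of the two numbers shown. Compound 2 `CCOC(=O)C1=C(Nc2ccc(C(F)(F)F)cc2)S/C(=C\c2ccc[nH]2)C1=O` gives 38.5% in this assay. Compound 3 `CCOC(=O)C1=C(Nc2ccc(CC)cc2)S/C(=C\c2ccc[nH]2)C1=O` shows < 10%, which is a limit of the assay and not a number (the limit of < 10% in this assay, at which 1 of the 3 values shown sits). Going by the values given here, the one measured step, a number at least 28.5 percentage points lower from compound 2 to compound 3 (beyond the scatter), changes the ring bound to the nitrogen, not the ring at the exocyclic double bond. Compound 4 `CCOC(=O)C1=C(Nc2ccccc2)S/C(=C\c2cccnc2)C1=O` differs from compound 1 by pyridin-3-yl in place of phenyl on a double-bonded chain carbon bound to a double-bonded ring carbon. Among the compounds with values here, no measured step touches this position, so a step beyond the scatter is not expected; compound 4 is estimated to sit near compound 1, at 22%, between 8% and 40%, meaning an expected step of a number 1.7 percentage points higher from compound 1 to compound 4 (within the scatter).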

Compound 4, a percentage reported as inhibition, at one concentration (the size of the read-out at that concentration, not a potency): 32.1%
The estimate for compound 4 lay 10.1 percentage points below the measured number; measured number inside the range.
By their numbers in this assay, from the lowest: compound 1; then compounds 4 and 2 (each within the scatter of the next). At a limit, below all of these: compound 3.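

In this assay, pyridin-3-yl in place of phenyl on a double-bonded chain carbon bound to a double-bonded ring carbon gives a number 11.8 percentage points higher from compound 1 to compound 4 (beyond the scatter). This position, which the earlier step on the ring bound to the nitrogen did not touch, therefore responds to a change of ring, with the rest of compound 1 held fixed. Nothing measured here accounts for this step. Open, as far as these compounds go, is whether pyridin-4-yl or a phenyl carrying a carboxylic acid would move the number at this place. Also open, from the compounds shown here alone, is whether the step carries over when trifluoromethyl or ethyl sits on the ring bound to the nitrogen.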